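A few compounds are considered here, and "the series" means these few. Any claim that something is new, unique, unknown or untested is made for them only; others in the source may bear on it.

Compound 1 `COc1cc2ncnc(NNC(=S)NC(=O)c3ccccc3F)c2cc1OC` was tested in a functional assay on KB cells (Homo sapiens) for cytotoxicity, read by MTT assay, with a stated time of 72 h (a lower number here means a stronger inhibitor, a higher number a weaker inhibitor), and gave 4070 nM. Compound 3 `O=C(NC(=S)NNc1ncnc2ccccc12)c1ccc(Cl)cc1` gave 3940 nM in this assay, and those two numbers lie within the scatter of each other, so neither can be called the stronger inhibitor. Compound 2 `COc1ccccc1C(=O)NC(=S)NNc1ncnc2ccccc12` reached only the limit of > 50000 nM in this assay. Going by the values given here, the one measured step, an at least 12-fold lower number from compound 2 to compound 3 (1.10 log units; beyond the scatter), shows that exchanging the group on the aromatic ring attached to the carbonyl can move the number a long way. Compound 4 `COc1cc2ncnc(NNC(=S)NC(=O)c3ccccc3)c2cc1OC` differs from compound 1 by hydrogen in place of fluoro on an aromatic carbon, a change on that same ring, but a smaller one, since only a single fluorine leaves and a hydrogen takes its place. The step from compound 2 to compound 3 is the nearest guide, yet a change of that size is not expected here, and the direction is uncertain. Compound 4 is expected to give about 5500 nM in this assay, with a likely range of 2000 nM to 15000 nM. That estimate amounts to a 1.4-fold higher number from compound 1 to compound 4 (0.13 log units; within the scatter), which is expected to stay within the scatter.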

Compound 4, half-maximal inhibitory concentration: 3770 nM
The estimate for compound 4 lay 1.5-fold (0.16 log units) above the measured number; the measured number falls inside the stated range.
By their numbers in this assay, from the lowest: compounds 4, 3 and 1 (each within the scatter of the next). At a limit, above all of these: compound 2.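

Taking away the fluoro group, so that 2-fluorophenyl becomes phenyl, gives a 1.1-fold lower number from compound 1 to compound 4 (0.03 log units; within the scatter) in this assay. The earlier compounds shown here showed that the aromatic ring on the carbonyl can matter a great deal, as in an at least 12-fold lower number from compound 2 to compound 3 (1.10 log units; beyond the scatter), but they did not test a single position on that ring with one group exchanged alone. Here, at a place ortho to a large group, fluoro and hydrogen cannot be told apart in this cell test, so the fluorine is not needed for the value seen with compound 1, and no measurement shown bears on why.

Still open, on these data alone, is whether a bigger or charged group at this same place, such as an amine or a carboxylic acid, would shift the number. As far as these compounds go, it is also open whether fluoro at other places on the ring would behave the same way.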